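Lengthening One Alkene Chain on Compound 2

This account rests on a few compounds, and the source may have more. Where it says the series, first, only, none or still open, it means among the compounds named here.

Measured so far in a functional assay on SK-MEL-28 cells (Homo sapiens) for inhibition, read by colorimetric assay and MTT assay, with a stated time of 72 h; a lower number here means a stronger inhibitor, a higher number a weaker inhibitor
Compound 1 `C=CCCCCOc1ccc(OC)cc1-c1cnc(OCCC=C)n1C`: 62000 nM
Compound 2 `C=CCCCCOc1cc2ccccc2cc1-c1cnc(OCCC=C)n1C`: 25000 nM

Compound 2 has the lower number of the two, and its gap to compound 1 lies beyond the usual scatter. Compound 3 `C=CCCCCOc1cc2ccccc2cc1-c1cnc(OCCCCC=C)n1C` differs from compound 2 in one place. The change but-3-en-1-yl in place of vinyl on a saturated chain carbon, two bonds along the chain from an oxygen on an aromatic ring puts but-3-en-1-yl in place of vinyl on a saturated chain carbon, two bonds along the chain from an oxygen on an aromatic ring. For the measured compounds named here, no measured pair shows this kind of change, so the expectation starts from compound 2 at 25000 nM as its only anchor. The expected step of a 1.3-fold lower number from compound 2 to compound 3 (0.10 log units; within the scatter) is small and slightly downward, not beyond the scatter. For compound 3 the estimated value is 20000 nM with an expected range from 8000 nM to 50000 nM in this measurement.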

Compound 3, half-maximal inhibitory concentration: 59000 nM
Beside the measured number, compound 3's estimate is 3.0-fold (0.47 log units) below it; the whole stated range lies below it.
By their numbers in this assay, from the lowest: compound 2; then compounds 3 and 1 (each within the scatter of the next).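

In this assay, putting but-3-en-1-yl in place of vinyl, on a saturated chain carbon two bonds along the chain from an oxygen on an aromatic ring, gives a 2.4-fold higher number from compound 2 to compound 3 (0.37 log units; beyond the scatter) and so a weaker inhibitor. This shows that the position responds to the length of this alkene chain, and that the longer (hex-5-en-1-yl)oxy group does not improve on (but-3-en-1-yl)oxy. No measurement here explains the loss.

A single step cannot establish a trend with chain length. As far as these compounds go, how a shorter allyl chain, or an amine or carboxylic acid at the chain end, would behave remains open.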